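Fluoromethyl for Methyl on the Branched Chain

A few compounds are considered here, and "the series" means these few. Any claim that something is new, unique, unknown or untested is made for them only; others in the source may bear on it.

Compounds measured so far:
compound 1, `COc1cc(C(c2ccc(O)c(OC)c2)[C@@H](C)[C@H](C)CO)ccc1O`, > 100000 nM in a functional assay on HL-60 cells (Homo sapiens) for cytotoxicity, read by WST assay, with a stated time of 48 h; on this read-out lower numbers stand for stronger inhibition and higher numbers for weaker inhibition
compound 2, `COc1cc(C(c2ccc(O)c(OC)c2)[C@H](CC(C)C)C(C)C)ccc1O`, 9600 nM
compound 3, `COc1cc(C(c2ccc(O)c(OC)c2)[C@H](C)C(C)C)ccc1O`, 17000 nM

Compound 1 reaches only the limit of this assay, (the limit of > 100000 nM in this assay, at which 1 of the 3 values shown sits). Among the two compounds with a number, compound 3 gives the higher one, with compound 2 the nearest; the two lie within the scatter of each other, a 1.8-fold higher number from compound 2 to compound 3 (0.25 log units; within the scatter).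

Compound 4, `COc1cc(C(c2ccc(O)c(OC)c2)[C@@H](CF)C(C)C)ccc1O`, has not yet been measured. It differs from compound 3 in one place: 1-(fluoromethyl)-2-methylpropyl in place of 1,2-dimethylpropyl on a saturated chain carbon bound to two aromatic carbons. Within the data shown here, two measured steps bear on this. From compound 1 to compound 3 the number fell, an at least 5.8-fold lower number from compound 1 to compound 3 (0.76 log units; beyond the scatter), when 1,2-dimethylpropyl replaced 2-(hydroxymethyl)-1-methylpropyl. From compound 2 to compound 3 the number moved only within the scatter, a 1.8-fold higher number from compound 2 to compound 3 (0.25 log units; within the scatter). The entering 1-(fluoromethyl)-2-methylpropyl carries no hydrogen-bond donor, unlike the group of compound 1, so a change no larger than the scatter, or a modest rise, is expected. Compound 4 is therefore estimated at 25000 nM, between 9000 nM and 70000 nM, an expected step of a 1.5-fold higher number from compound 3 to compound 4 (0.17 log units; within the scatter).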

Compound 4, half-maximal inhibitory concentration: 39000 nM
Compound 4: middle estimate off by 1.6-fold (0.19 log units), on the low side, and the stated range covers the measured number.
By their numbers in this assay, from the lowest: compounds 2 and 3 (each within the scatter of the next); then compound 4. At a limit, above all of these: compound 1.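

In this assay, a single fluorine on the branched chain is enough to carry the number beyond the scatter, a 2.3-fold higher number from compound 3 to compound 4 (0.36 log units; beyond the scatter), a modest change at a place where the exchange between the two purely hydrocarbon chains had stayed within it. Set against the 1-isopropyl-3-methylbutyl group, the 1-(fluoromethyl)-2-methylpropyl group gives a 4.1-fold higher number from compound 2 to compound 4 (0.61 log units; beyond the scatter), so a chain with no hydrogen-bond donor can still lose ground here. Even so, the fluoromethyl chain keeps a measurable number where the hydroxymethyl chain does not, an at least 2.5-fold lower number from compound 1 to compound 4 (0.40 log units; beyond the scatter), and that step rests on a limit rather than a number: the limit of > 100000 nM in this assay, at which 1 of the 4 values shown sits.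

On these data alone, whether the rise belongs to fluorine itself or to any atom added at that carbon stays open. Chloromethyl, difluoromethyl, methoxymethyl or aminomethyl groups in the same place would bear on this.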